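Removing an N-methyl group on a smaller amino-pyrazole core

The source may hold more compounds than are shown below. What is called first, only, known or untested is meant among the compounds shown, and "the series" means these compounds.

Compound 1 `Nc1n[nH]c2cc(-c3ccccn3)[nH]c(=O)c12` — 24%
Compound 2 `Cn1nc(N)c2c(=O)[nH]c(-c3ccccn3)cc21` — 9%
Compound 3 `Cc1cc2c(cn1)c(N)nn2C` — 1%

Of the compounds shown here, three have been measured in an assay on isolated protein for inhibition of ribosomal protein S6 kinase alpha-1 (Homo sapiens), read by mobility shift assay, tested at 30 uM; a lower number here means less inhibition, a higher number more inhibition at the concentration tested (going by the name of the read-out). Compound 1 gives 24%, the highest of the three numbers. Compound 2, which carries a methyl on the five-membered ring, gives 9%. Compound 3, built on a smaller two-ring core, gives 1%; the gap between compound 3 and compound 2 lies within the scatter, while the gap to compound 1 lies beyond it.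

The change from compound 2 to compound 1 is hydrogen in place of methyl on an aromatic nitrogen; the step was a number 15 percentage points higher from compound 2 to compound 1 (beyond the scatter).

Compound 4 `Cc1cc2[nH]nc(N)c2cn1` has not yet been measured. It differs from compound 3 by hydrogen in place of methyl on an aromatic nitrogen, the same change as that from compound 2 to compound 1, made at a place described in the same words. How the core of compound 3 differs from that of compound 2 is not broken down here.

Going by the values given here, on the strength of the one earlier step, the step from compound 3 to compound 4 is expected to be a number 9 percentage points higher from compound 3 to compound 4 (within the scatter), somewhat smaller than the modest rise seen earlier, because compound 3 starts from 1% and its core is the smaller one. Compound 4 is therefore estimated to give 10%, with a range from 0% to 25%.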

Compound 4, a percentage reported as inhibition, at one concentration (the size of the read-out at that concentration, not a potency): 11%
Compound 4: middle estimate off by 1 percentage points, on the low side, and the stated range covers the measured number.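

In this assay, hydrogen in place of methyl on an aromatic nitrogen comes with a number 10 percentage points higher from compound 3 to compound 4 (within the scatter), so on the core of compound 3 this step alone cannot be told apart from the usual variation between repeated measurements. Set beside the step on the other core, the two cannot be told apart either: the same change on two cores in this assay, a number 15 percentage points higher (beyond the scatter) from compound 2 to compound 1 and a number 10 percentage points higher (within the scatter) from compound 3 to compound 4, 5 percentage points apart, within the scatter of two such steps This shows that the change points the same way on both cores and that the size of the step is comparable, but only the step on the core of compound 2 lies beyond the scatter, and two cores, each read at a single concentration, do not show that the change would carry over to every core in this series or why it has this result.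

The compounds shown have only hydrogen or methyl on that aromatic nitrogen, so it remains open how an ethyl group or a longer chain would read there. Going by these compounds, it also remains open whether the same step would appear with an amide or a carboxylic acid on the ring atom that now bears the amino group.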